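Sulfonyl-bearing core: swapping methylpiperazine for imidazole

The source may report more compounds than this note shows. Statements on the series, on what has been measured and on what is new or still open speak of the compounds shown alone.

Measured compounds:
compound 1 `CN1CCN(c2ccc(C3=NNC(c4ccc(N(C)C)cc4)C3)cc2)CC1` — 31.2%
compound 2 `CC(=O)N1N=C(c2ccc(N3CCN(C)CC3)cc2)CC1c1ccc(N(C)C)cc1` — -0.8%
compound 3 `CN1CCN(c2ccc(C3=NN(S(=O)(=O)c4ccc(C#N)cc4)C(c4ccc(N(C)C)cc4)C3)cc2)CC1` — 99.8%

Compound 3 gives the highest of the three numbers in a functional assay on HCC1806 cells (Homo sapiens) for inhibition, read by sulforhodamine B assay, tested at 10 uM; a lower number here means less inhibition, a higher number more inhibition at the concentration tested (going by the name of the read-out). Its lead over compound 1 is a number 68.6 percentage points higher from compound 1 to compound 3 (beyond the scatter), and over compound 2 it is a number 100.6 percentage points higher from compound 2 to compound 3 (beyond the scatter); the step from compound 1 to compound 2, with acetyl in place of hydrogen on the ring amine nitrogen, was a number 32 percentage points lower from compound 1 to compound 2 (beyond the scatter). All three measured steps concern the substituent on that ring nitrogen only.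

Compound 4 `CN(C)c1ccc(C2CC(c3ccc(-n4ccnc4)cc3)=NN2S(=O)(=O)c2ccc(C#N)cc2)cc1` keeps the (4-cyanophenyl)sulfonyl of compound 3 and differs elsewhere: 1H-imidazol-1-yl in place of 4-methylpiperazin-1-yl on an aromatic carbon. Among the measured compounds shown here, no measured step touches this part of the molecule, so none of the recorded steps bears directly on the change; they show only that the number of compound 3 in this assay is the highest of the three at this concentration. With that substituent retained, compound 4 is expected to stay in the high range, with the untested ring swap leaving room for a moderate loss, so the expected step is a number 14.8 percentage points lower from compound 3 to compound 4 (beyond the scatter). Compound 4 is therefore estimated at 85%, within 50% to 100%.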

Compound 4, a percentage reported as inhibition, at one concentration (the size of the read-out at that concentration, not a potency): 4.7%
Compound 4: middle estimate off by 80.3 percentage points, on the high side; measured number below the stated range.
By their numbers in this assay, from the lowest: compounds 2 and 4 (each within the scatter of the next); then compound 1; then compound 3.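

In this assay, the aromatic carbon para to a large group proves decisive: 1H-imidazol-1-yl in place of 4-methylpiperazin-1-yl gives a number 95.1 percentage points lower from compound 3 to compound 4 (beyond the scatter), so keeping the (4-cyanophenyl)sulfonyl group on the ring nitrogen does not by itself preserve the read-out. Among the compounds shown here, the earlier steps varied only that ring-nitrogen substituent with 4-methylpiperazin-1-yl held fixed, whereas this step shows that the read-out of the sulfonyl compounds also depends on the group at this second place. The two groups differ in ring size, aromaticity and heavy-atom count but match in hydrogen-bond donor and acceptor counts and in having no net charge, and no available evidence shows which difference, if any, accounts for the step.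

The compounds shown leave open whether a morpholine or piperidine ring at this carbon, or an open-chain dimethylamino group, would keep the read-out of compound 3, which would help separate ring size and aromaticity from the identity of the ring atoms. They also leave open how 1H-imidazol-1-yl behaves with any ring-nitrogen substituent other than (4-cyanophenyl)sulfonyl.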